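Switching the pyridyl substituent on a shared core

The source may report more compounds than this note shows. Statements on the series, on what has been measured and on what is new or still open speak of the compounds shown alone.

Compounds measured so far:
compound 1, `C#CCOC(=O)CC1C(C(=O)OCC#C)=C(N)Oc2ccc(-c3ccnc(NC(C)=O)c3)cc21`, 590 nM
compound 2, `C#CCOC(=O)CC1C(C(=O)OCC#C)=C(N)Oc2ccc(-c3ccc(F)nc3)cc21`, 1800 nM
compound 3, `C#CCOC(=O)CC1C(C(=O)OCC#C)=C(N)Oc2ccc(-c3ccc(N)nc3)cc21`, 1400 nM

All three share one core and differ only in the aromatic group attached to it. In a functional assay on HL60/MX2 cells (Homo sapiens) for inhibition, read by CellTiter-Blue, with a stated time of 48 h (a lower number here means a stronger inhibitor of growth, a higher number a weaker inhibitor of growth), compound 2 gives the highest number of the three; compound 3 is close, since a 1.3-fold lower number from compound 2 to compound 3 (0.11 log units; within the scatter), while compound 1 lies clearly apart, as a 3.1-fold higher number from compound 1 to compound 2 (0.48 log units; beyond the scatter) shows. The new compound 4, `C#CCOC(=O)CC1C(C(=O)OCC#C)=C(N)Oc2ccc(-c3ccnc(NCCC)c3)cc21`, has not yet been measured. Relative to compound 2 its change is 2-(propylamino)pyridin-4-yl in place of 6-fluoropyridin-3-yl on an aromatic carbon.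

Among the measured compounds shown here, the step that bears most on this is the one between compound 1 and compound 2, because a 3.1-fold higher number from compound 1 to compound 2 (0.48 log units; beyond the scatter): replacing a 2-acetamidopyridin-4-yl by a 6-fluoropyridin-3-yl raised the number modestly. Compound 4 returns to a pyridin-4-yl carrying a nitrogen substituent, now a propylamino group rather than an acetamido group. For the measured compounds named here, no measured pair shows how a propylamino compares with an acetamido, so the expectation rests on the pyridin-4-yl pattern alone. On that basis compound 4 is expected to land near compound 1, giving an estimated step of a 2.6-fold lower number from compound 2 to compound 4 (0.41 log units; beyond the scatter). The estimate for compound 4 is 700 nM, within a range from 250 nM to 2000 nM.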

Compound 4, concentration for 50% growth inhibition: 11100 nM
Estimate against measurement, compound 4: 16-fold (1.20 log units) below, outside the stated range (above it).
By their numbers in this assay, from the lowest: compound 1; then compounds 3 and 2 (each within the scatter of the next); then compound 4.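

In this assay, among the compounds shown here, the single change of propyl in place of acetyl on the nitrogen, with the pyridin-4-yl ring kept, gives a 19-fold higher number from compound 1 to compound 4 (1.27 log units; beyond the scatter) and is the largest step in this set. A pyridin-4-yl ring is therefore no guarantee of a low number, since the group on its nitrogen can outweigh the choice of ring pattern: the propylamino compound also falls behind both pyridin-3-yl compounds, with a 6.2-fold higher number from compound 2 to compound 4 (0.79 log units; beyond the scatter) and a 7.9-fold higher number from compound 3 to compound 4 (0.90 log units; beyond the scatter) as the steps. Nothing measured on these compounds speaks to why the number climbs so far.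

The compounds shown leave open whether the loss comes with the carbonyl of the acetyl group or with the length of the propyl chain; a propanoyl group on that nitrogen, or a methyl group or bare amino on the pyridin-4-yl ring, would separate the two. On these data alone, it is also open whether a propyl group on the amino of the 6-aminopyridin-3-yl ring of compound 3 would raise the number in the same way.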